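This account rests on a few compounds, and the source may have more. Where it says the series, first, only, none or still open, it means among the compounds named here.

Measured so far:
Compound 1 `O=S(=O)(CC1=NCCS1)C1=NNCC1c1ccccc1` gives "not active" (no number reported) in a functional assay, tested at 50 ug/mL; a higher number here means a stronger effect of the compound at the concentration tested, a lower number a weaker effect.
Compound 2 `Cc1ccc(C2CNN=C2S(=O)(=O)CC2=NCCO2)cc1` gives 41.3% in this assay.
Compound 3 `O=S(=O)(CC1=NCCO1)C1=NNCC1c1ccc(Cl)cc1` gives "not active" (no number reported) in this assay.

Among these three, compound 2 is the only one for which this assay returned a number at all. Compound 1 is reported in this assay only as "not active" (no number reported), and compound 3 only as "not active" (no number reported), so neither can be set against compound 2 as a counted step; all the two entries show is an absence of a measurable effect where compound 2 gave one.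

Compound 4 `Cc1ccc(C2CNN=C2S(=O)(=O)CC2=NCCS2)cc1` has not been measured. It differs from compound 2 in a single place: a group of 5 heavy atoms (3 carbon, 1 nitrogen, 1 sulfur; one five-membered non-aromatic ring with 2 hetero atoms) in place of a group of 5 heavy atoms (3 carbon, 1 nitrogen, 1 oxygen; one five-membered non-aromatic ring with 2 hetero atoms), on a saturated chain carbon bound to a sulfonyl sulfur. Going by the values given here, no measured pair shows this exchange on its own. The nearest pointer is compound 1, which carries the same entering ring and is reported in this assay as "not active" (no number reported); on that showing a weaker result is expected for compound 4. The expected step is a number 19.3 percentage points lower from compound 2 to compound 4 (beyond the scatter), a drop beyond the usual scatter. For compound 4 the estimated activity in this assay is 22%, with a range from 3% to 42%.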

Compound 4, a percentage reported as activity, at one concentration (the size of the read-out at that concentration, not a potency): 39.8%
Compound 4: the middle estimate sits 17.8 percentage points below what was measured; low and high end bracket the measured number.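

In this assay the exchange of the oxygen-bearing five-membered ring for its sulfur-bearing counterpart, on a saturated chain carbon bound to a sulfonyl sulfur, gives a number 1.5 percentage points lower from compound 2 to compound 4 (within the scatter) and so does not separate the two rings at this place. Going by these compounds alone, this is the first counted step at this position, and it shows that the sulfur-bearing ring can carry a measurable read-out: the methyl group of compound 4 is absent from compound 1, which has this ring and gives "not active" (no number reported) in this assay, while compound 4 gives 39.8% in the same test. Nothing given here accounts for the near-identical results of the oxygen and sulfur rings.

From the compounds shown here alone, because only these two rings are compared at this position, it remains open whether a quite different group there, such as an open-chain amine or a carboxylic acid, would keep the read-out. Going by these compounds, it is also open whether the sulfur-bearing ring would give a number alongside the chlorine of compound 3, which like compound 1 has no number to count from.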